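Dichlorophenoxy to fluorophenoxy: the step from compound 1

This account rests on a few compounds, and the source may have more. Where it says the series, first, only, none or still open, it means among the compounds named here.

compound 1 `Nc1cc(N)c2nc(-c3ccccc3)c(Oc3ccc(Cl)c(Cl)c3)nc2c1`: 66100 nM
compound 2 `CCOC(=O)[C@H](CCC(=O)O)NC(=O)c1ccc(CNc2nc3cc(N)cc(N)c3nc2-c2ccccc2)cc1`: < 100000 nM (a limit)

Among the compounds with values here, in a functional assay on MDA-MB-231 cells (Homo sapiens) for inhibition, read by sulforhodamine B assay, with a stated time of 48 h (on this read-out lower numbers stand for higher toxicity in this test and higher numbers for lower toxicity in this test), compound 1 gives 66100 nM, the only number in hand. Compound 2 returns only a limit in this assay, (the limit of < 100000 nM in this assay, at which 1 of the 2 values shown sits). Compound 3 `Nc1cc(N)c2nc(-c3ccccc3)c(Oc3ccc(F)cc3)nc2c1` is drawn from compound 1 by 4-fluorophenyl in place of 3,4-dichlorophenyl on an oxygen on an aromatic ring. Within the data shown here, no step between two measured compounds is available, so the effect of this exchange rests on nothing measured. The working expectation is a change no larger than the scatter, in either direction. Compound 3 is therefore estimated at 66000 nM, within 22000 nM to 200000 nM. The expected step from compound 1 to compound 3 is a 1.0-fold lower number from compound 1 to compound 3 (0.00 log units; within the scatter).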

Compound 3, concentration lethal to 50% of the cells: < 100000 nM
Compound 3 ended at the assay's limit (the forecaster's own chance of this, stated with the estimate: 25%); the middle value does not contradict the limit.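

Compound 3 gives < 100000 nM, a limit and not a number, so the step from compound 1 to compound 3 cannot be read. Whether 4-fluorophenyl in place of 3,4-dichlorophenyl changes the read-out in this assay stays open: the limit of < 100000 nM in this assay, at which 2 of the 3 values shown sit.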